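Hydroxymethyl for bromo on the benzyl of compound 3

The source may hold more compounds than are shown below. What is called first, only, known or untested is meant among the compounds shown, and "the series" means these compounds.

Measured so far in a physicochemical assay for solubility, using the shake flask method, in simulated intestinal fluid, measured as kinetic solubility, with a stated time of 2 h, at 25 degrees C, at pH 6.5; a lower number here means a less soluble compound, a higher number a more soluble compound:
Compound 1 `CCCOC(=O)c1nc(C)c2c(c1N)C(=O)N(Cc1ccccc1)C2=O` gives < 5000 nM, a limit.
Compound 2 `Cc1nnc(-c2nc(C)c3c(c2N)C(=O)N(Cc2ccccc2)C3=O)o1` gives < 5000 nM, a limit.
Compound 3 `Cc1noc(-c2nc(C)c3c(c2N)C(=O)N(Cc2ccc(Br)cc2)C3=O)n1` gives < 5000 nM, a limit.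

None of the three values is a number; (the limit of < 5000 nM in this assay, at which 3 of the 3 values shown sit). Compound 3 thus stands at the limit of this assay, and no number places it against compound 1 or compound 2. Among the measured compounds shown here, the one step between measured compounds, a step that the two limits leave unreadable from compound 1 to compound 2, runs between two limits and has no readable size, so it says nothing about direction either.

Compound 4 `Cc1noc(-c2nc(C)c3c(c2N)C(=O)N(Cc2ccc(CO)cc2)C3=O)n1` differs from compound 3 by hydroxymethyl in place of bromo on an aromatic carbon. For the measured compounds named here, no measured step concerns this change; nothing in the measured set fixes its size or direction. With the entering hydroxymethyl, compound 4 is expected to sit at or somewhat above the limit seen for compound 3. The estimated step is an at least 1.6-fold higher number from compound 3 to compound 4 (0.20 log units; that floor lies within the scatter). Compound 4 is expected to give about 8000 nM, within 2500 nM to 30000 nM, with a fair chance that only a limit is again reported.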

Compound 4, solubility: < 5000 nM
Compound 4: only a limit was reported; the forecaster's own chance of this, stated with the estimate: 40%; middle value at least 1.6-fold (0.20 log units) from the limit.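

Compound 3 and compound 4 both stand only as limits, so no step between them can be read in this assay: the limit of < 5000 nM in this assay, at which 4 of the 4 values shown sit.

The compounds shown leave open the size and direction of the change from bromo to hydroxymethyl, and how any of the four compounds ranks against the others.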